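Cytotoxicity in a small series, every value a limit

The source may report more compounds than this note shows. Statements on the series, on what has been measured and on what is new or still open speak of the compounds shown alone.

Measured so far:
compound 1 `Cc1c(C(=O)N/N=C/c2ccc([N+](=O)[O-])cc2)no[n+]1[O-]` in an ADME assay on J774.1 cells (Mus musculus) for cytotoxicity, read by MTT assay, with a stated time of 48 h; a higher number here means a weaker inhibitor, a lower number a stronger inhibitor: > 300000 nM
compound 2 `Cc1nc2ccccn2c1C(=O)N/N=C/c1no[n+]([O-])c1C`: > 400000 nM
compound 3 `Cc1c(/C=N/NC(=O)c2no[n+]([O-])c2C)no[n+]1[O-]`: > 400000 nM

Each of these values is a limit of this assay and not a number. Compound 1 sits at the limit of > 300000 nM in this assay, at which 1 of the 3 values shown sits. Compound 2 sits at the limit of > 400000 nM in this assay, at which 2 of the 3 values shown sit. Compound 3 sits at the same limit. Compound 1 therefore cannot be placed in any order; it is known only as weak. Compound 4 `Cc1c(C(=O)N/N=C/c2ccccc2)no[n+]1[O-]` remains to be measured and differs from compound 1 by hydrogen in place of nitro on an aromatic carbon, the nitro leaving and hydrogen entering on an aromatic carbon of a six-membered aromatic ring of carbon only. Among the measured compounds shown here, no step between measured compounds is available, so the expected change in this assay is none beyond the scatter. Compound 4 is expected to give 400000 nM, between 150000 nM and 1500000 nM, most likely again as a limit. The step is estimated as a step that the limit leaves unreadable from compound 1 to compound 4.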

Compound 4, half-maximal inhibitory concentration: > 400000 nM
Compound 4 ended at the assay's limit; the forecaster's own chance of this, stated with the estimate: 85%; the middle value sits exactly at the limit.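

Compound 1 and compound 4 both stand as limits and not as numbers, so no step can be read for hydrogen in place of nitro. The compounds shown leave open where any of them would reach half-maximal inhibition in this assay.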